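Methylsulfonyl on the ring amine nitrogen: working notes

This account rests on a few compounds, and the source may have more. Where it says the series, first, only, none or still open, it means among the compounds named here.

Values in a physicochemical assay for solubility, at pH 6.8 (on this read-out lower numbers stand for lower solubility and higher numbers for higher solubility), for the series:
- compound 1 `CN1CCc2nc(C(=O)NC3CNCCC3NC(=O)c3cc4cc(Cl)ccc4[nH]3)sc2C1` gives 996 ug/mL
- compound 2 `CN1CCc2nc(C(=O)NC3CN(S(C)(=O)=O)CCC3NC(=O)c3cc4cc(Cl)ccc4[nH]3)sc2C1` gives 103 ug/mL
- compound 3 `CN1CCc2nc(C(=O)NC3CCNCC3NC(=O)c3cc4cc(Cl)ccc4[nH]3)sc2C1` gives 830 ug/mL
- compound 4 `CN1CCc2nc(C(=O)NC3CCN(S(C)(=O)=O)CC3NC(=O)c3cc4cc(Cl)ccc4[nH]3)sc2C1` is not yet measured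

The values of compound 1 and compound 3 lie within the usual scatter of each other, so neither is placed above the other. Both sit well above compound 2 (103 ug/mL).

The next change takes compound 3 to compound 4, with methylsulfonyl in place of hydrogen on an amine nitrogen in a ring. Among the measured compounds shown here, one measured step bears on it, as the same replacement gave a 9.7-fold lower number from compound 1 to compound 2 (0.99 log units; beyond the scatter) (modest in size, beyond the scatter). For the measured compounds named here, this is the only such step available, and its starting point, compound 1, is not the same structure as compound 3, so the size may not carry over exactly and the range is kept wide.

In this assay a lower number of similar size is expected, and the estimated step is a 9.2-fold lower number from compound 3 to compound 4 (0.96 log units; beyond the scatter) (a single precedent). Compound 4 is estimated at 90 ug/mL (expected range 35 ug/mL to 230 ug/mL).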

Compound 4, solubility: 70 ug/mL
Beside the measured number, compound 4's estimate is 1.3-fold (0.11 log units) above it, within the range that was stated.
By their numbers in this assay, from the lowest: compounds 4 and 2 (each within the scatter of the next); then compounds 3 and 1 (each within the scatter of the next).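

In this assay methylsulfonyl in place of hydrogen on an amine nitrogen in a ring now gives a 12-fold lower number from compound 3 to compound 4 (1.07 log units; beyond the scatter) and so no longer rests on a single pair. The earlier step, a 9.7-fold lower number from compound 1 to compound 2 (0.99 log units; beyond the scatter) and likewise beyond the scatter, runs the same way, so the lower number holds in both listed pairs, with the ring nitrogen placed as in compound 1 and as in compound 3, and no listed pair goes against it. The data in hand offer nothing that explains the size of either step.

Going by these compounds, whether a smaller group on the same ring nitrogen, such as acetyl or methyl, would also give a step of this size in this assay stays open. Also open, on these data alone, is how a carboxylic acid or a longer chain at that nitrogen would compare with the free amine of compound 3 and with the methylsulfonyl of compound 4.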